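Replacing a Tetrazolylphenyl Group with a Fluorinated Methylsulfonylphenyl Group

The source may report more compounds than this note shows. Statements on the series, on what has been measured and on what is new or still open speak of the compounds shown alone.

Compound 1 `C[C@@H]1CN(C(=O)OC(C)(C)C)CCN1c1ncc(OCC2CCN(S(C)(=O)=O)CC2)cn1` gives 29 nM in an in vitro functional assay on HEK293S cells for agonist activity at Glucose-dependent insulinotropic receptor (Homo sapiens), read by HTRF and cAMP accumulation, with a stated time of 45 min; on this read-out higher numbers stand for an effect only at larger amounts of compound and lower numbers for an effect already at smaller amounts.
Compound 2 `C[C@@H]1CN(C(=O)OC(C)(C)C)CCN1c1ncc(OCc2ccc(-n3cnnn3)cc2)cn1` gives 6 nM in this assay.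

Within the data shown here, compound 2 stands at the lowest of these two numbers; its only neighbour is compound 1, and the step of a 4.8-fold lower number from compound 1 to compound 2 (0.68 log units; beyond the scatter) lies beyond the scatter. Compound 3 `C[C@@H]1CN(C(=O)OC(C)(C)C)CCN1c1ncc(OCc2ccc(S(C)(=O)=O)cc2F)cn1` is not yet measured. It differs from compound 2 by 2-fluoro-4-(methylsulfonyl)phenyl in place of 4-(1H-tetrazol-1-yl)phenyl on a saturated chain carbon bound to an oxygen on an aromatic ring. Among the measured compounds shown here, one measured step bears on this change: a 4.8-fold lower number from compound 1 to compound 2 (0.68 log units; beyond the scatter), where a methylsulfonyl-bearing saturated ring was exchanged for the tetrazolylphenyl group at the same place, and the number fell. Compound 3 keeps a methylsulfonyl group, now on a phenyl ring carrying a fluorine, so the tetrazole is given up without going all the way back to compound 1. Compound 3 is therefore expected to show a modest rise in the number, a 2.0-fold higher number from compound 2 to compound 3 (0.30 log units; within the scatter). For compound 3 the estimated value in this assay is 12 nM, with a range from 4 nM to 40 nM.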

Compound 3, half-maximal effective concentration: 3 nM
For compound 3 the middle estimate is 4.0-fold (0.60 log units) above the measured one; measured number outside the range, below it.
By their numbers in this assay, from the lowest: compounds 3 and 2 (each within the scatter of the next); then compound 1.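

At this place, on a saturated chain carbon bound to an oxygen on an aromatic ring, the tetrazole is not required for a low number in this assay: the swap to 2-fluoro-4-(methylsulfonyl)phenyl gives a 2.0-fold lower number from compound 2 to compound 3 (0.30 log units; within the scatter) and so leaves the two groups level. The methylsulfonyl group also behaves differently on this phenyl ring than on the saturated ring, with a 9.7-fold lower number from compound 1 to compound 3 (0.99 log units; beyond the scatter) on exchanging 1-(methylsulfonyl)piperidin-4-yl for the fluorinated phenyl group. No measurement is available to explain either result.

On these data alone, what the fluorine contributes stays open, since separating it from the methylsulfonyl group would take a plain 4-(methylsulfonyl)phenyl group. Also open, as far as these compounds go, is whether a carboxylic acid or an amine on that phenyl ring would keep the number this low.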